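The compounds below may be only part of what the source reports. "The series", "measured", "known", "first", "only" and "open" are said of these compounds alone.

Of the compounds shown here, two sharing one core have been measured in a functional assay on MDA-MB-435 cells (Homo sapiens) for antiproliferative activity, read by sulforhodamine B assay, with a stated time of 48 h; a higher number here means a weaker inhibitor, a lower number a stronger inhibitor. Compound 1 `COc1ccc(-c2nsc3c2NC(=O)CC3c2cccc(OC)c2)cc1` gives 282 nM, and compound 2 `COc1ccc(-c2nsc3c2NC(=O)CC3c2ccc(F)cc2)cc1` gives 440 nM. These two numbers lie within the usual scatter of each other, so compound 2 cannot be separated from compound 1 on this evidence. Compound 3 `COc1ccc(-c2nsc3c2NC(=O)CC3c2ccsc2)cc1` keeps the core of compound 2 but carries thiophen-3-yl in place of 4-fluorophenyl on a saturated ring carbon. Among the measured compounds shown here, no compound with thiophen-3-yl has been measured, so no step tests this exchange directly. For the measured compounds named here, the only measured step that bears on it is a change of group at the same ring carbon, a 1.6-fold higher number from compound 1 to compound 2 (0.19 log units; within the scatter), where 4-fluorophenyl took the place of 3-methoxyphenyl. One small step is thin evidence, but it gives no reason to expect a large shift in this assay, and no direction can be drawn from it. The expected result is a 1.1-fold lower number from compound 2 to compound 3 (0.04 log units; within the scatter), which means no step beyond the scatter. For compound 3 the estimated value is 400 nM, with an expected range from 150 nM to 1100 nM.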

Compound 3, half-maximal inhibitory concentration: 23.5 nM
The estimate for compound 3 lay 17-fold (1.23 log units) above the measured number, and the stated range ends above it.
By their numbers in this assay, from the lowest: compound 3; then compounds 1 and 2 (each within the scatter of the next).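

The saturated ring carbon, three ring bonds from the ring nitrogen, proved far more sensitive to its group than the earlier pair suggested. In this assay, exchanging either six-membered aromatic ring for thiophen-3-yl gives a large step, with a 19-fold lower number from compound 2 to compound 3 (1.27 log units; beyond the scatter) and a 12-fold lower number from compound 1 to compound 3 (1.08 log units; beyond the scatter), whereas the exchange of 3-methoxyphenyl for 4-fluorophenyl, a 1.6-fold higher number from compound 1 to compound 2 (0.19 log units; within the scatter), had stayed within the scatter. The two steps to compound 3 thus show that this position can respond strongly to the group it carries, although no measurement shown here accounts for the difference.

The exchange changes the ring size and brings in a sulfur atom at the same time, so the compounds shown leave open which of the two matters, a question that furan-3-yl or unsubstituted phenyl on this carbon would bear on. They also leave open whether this carbon needs an aromatic ring at all, and how a cyclopentyl group or a ring carrying an amine would compare with thiophen-3-yl in this assay.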